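Taking One Methoxy Group Off Compound 1

The compounds below may be only part of what the source reports. "The series", "measured", "known", "first", "only" and "open" are said of these compounds alone.

Compound 1 `COc1cc(/C=N/Nc2nc3ccccc3s2)ccc1O`: > 200 ug/mL
Compound 2 `Fc1ccc(/C=N/Nc2nc3ccccc3s2)c(F)c1`: > 200 ug/mL
Compound 3 `COc1ccc(/C=N/Nc2nc3ccccc3s2)c(OC)c1`: > 200 ug/mL

These three compounds were tested in a toxicity assay on cells (Erythrocyte, Mus musculus) for activation, read by spectrophotometry and hemolysis, with a stated time of 30 min; a lower number here means that less compound is needed, a higher number that more compound is needed for the effect. Compound 1 gives > 200 ug/mL, which is a limit of the assay and not a number. Compound 2 gives > 200 ug/mL, also a limit. Compound 3 gives > 200 ug/mL, again a limit. The whole set therefore stands at one reading: the limit of > 200 ug/mL in this assay, at which 3 of the 3 values shown sit.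

Compound 4 `Oc1ccc(/C=N/Nc2nc3ccccc3s2)cc1` has not yet been measured in this assay. It differs from compound 1 by hydrogen in place of methoxy on an aromatic carbon, ortho to a hydroxy group (hydrogen in place of methoxy on an aromatic carbon). Within the data shown here, no measured pair shows this change on its own, so the expectation rests only on the three limits. The expected step, a number no higher from compound 1 to compound 4 (the limit leaves the size open), is none beyond the scatter, in either direction. The result will most likely be reported as a limit again. The estimate for compound 4 is 200 ug/mL, with an expected range from 100 ug/mL to 400 ug/mL.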

Compound 4, half-maximal effective concentration: > 200 ug/mL
Compound 4 ended at the assay's limit; the forecaster's own chance of this, stated with the estimate: 85%; the middle value lies on the limit itself.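

Among these compounds, compound 1 and compound 4 both end at a limit in this assay, so no step between them can be read. The set stands at one reading: the limit of > 200 ug/mL in this assay, at which 4 of the 4 values shown sit.

The compounds shown leave open at what concentration any of them would reach the effect, and whether removing the methoxy group changes that concentration.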